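This account rests on a few compounds, and the source may have more. Where it says the series, first, only, none or still open, it means among the compounds named here.

In a functional assay on MCF7 cells (Homo sapiens) for inhibition, read by MTT assay, with a stated time of 72 h, tested at 10 uM (a higher number here means more inhibition at the concentration tested (going by the name of the read-out), a lower number less inhibition), compound 3 `CCOC(=O)C1=C(Nc2ccccc2)S/C(=C\c2cc3ccncc3[nH]2)C1=O` gives 18.2%. Compound 2 `CCOC(=O)C1=C(Nc2ccccc2)S/C(=C\c2cc3cccnc3[nH]2)C1=O` gives 18.2% in the same test, so there is no change at the digits printed from compound 2 to compound 3 (within the scatter), and the two stand together as the lowest of the three numbers. Compound 1 `CCOC(=O)C1=C(Nc2ccccc2)S/C(=C\c2ccc(O)c(O)c2)C1=O` gives 38.1% and is the furthest of the three from compound 3, with a number 19.9 percentage points lower from compound 1 to compound 3 (beyond the scatter) and, in the parallel comparison, a number 19.9 percentage points lower from compound 1 to compound 2 (beyond the scatter). Compound 4 `CCOC(=O)C1=C(Nc2ccccc2)S/C(=C\c2cc3ncccc3[nH]2)C1=O` is the next member of the set: a group of 9 heavy atoms (7 carbon, 2 nitrogen; one five-membered aromatic ring with 1 hetero atom, one six-membered aromatic ring with 1 hetero atom) in place of a group of 9 heavy atoms (7 carbon, 2 nitrogen; one five-membered aromatic ring with 1 hetero atom, one six-membered aromatic ring with 1 hetero atom), on a double-bonded chain carbon bound to a double-bonded ring carbon. For the measured compounds named here, the one measured step that bears directly on this change is the one from compound 2 to compound 3, which also exchanged one such group for another of the same kind and gave no change at the digits printed from compound 2 to compound 3 (within the scatter); the two steps from compound 1 replaced a group of a different kind and say less about it. A step of a number 0.2 percentage points lower from compound 3 to compound 4 (within the scatter) is therefore expected, lying within the scatter. The estimate for compound 4 is 18%, with a range from 8% to 30%.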

Compound 4, a percentage reported as inhibition, at one concentration (the size of the read-out at that concentration, not a potency): 42.2%
The estimate for compound 4 lay 24.2 percentage points below the measured number; the measured number lies above the stated range.
By their numbers in this assay, from the lowest: compounds 2 and 3 (each within the scatter of the next); then compounds 1 and 4 (each within the scatter of the next).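

At the double-bonded chain carbon bound to a double-bonded ring carbon, this assay can separate groups that have the same atoms, joined differently, as a number 24 percentage points higher from compound 3 to compound 4 (beyond the scatter) and a number 24 percentage points higher from compound 2 to compound 4 (beyond the scatter) both show. The earlier exchange of one such group for another, no change at the digits printed from compound 2 to compound 3 (within the scatter) at the time, gave no hint of this, so the arrangement of atoms in the group matters here, not merely its composition. The step of a number 4.1 percentage points higher from compound 1 to compound 4 (within the scatter) adds that a group of this kind can also stand within the scatter of the group of 8 heavy atoms it replaced.

Nothing shown here explains why the way these atoms are joined changes the read-out. Going by these compounds, it also remains open how a group bearing an amine or a carboxylic acid would behave at this same carbon.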